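The source may report more compounds than this note shows. Statements on the series, on what has been measured and on what is new or still open speak of the compounds shown alone.

Measured so far in a functional assay on CCRF-CEM cells (Homo sapiens) for inhibition; a higher number here means a weaker inhibitor, a lower number a stronger inhibitor:
- compound 1, `CCC(C)C(NC(=O)n1nnc2ccccc21)C(=O)NC1CCCCC1`: gives 107000 nM.
- compound 2, `CC(C)C(NC(=O)n1nnc2ccccc21)C(=O)NC1CCCC1`: gives > 200000 nM, which is a limit of the assay and not a number.

For compound 2 this assay reports only a limit, (the limit of > 200000 nM in this assay, at which 1 of the 2 values shown sits), so its place on the numbers is open-ended rather than fixed. Going by the values given here, the reading for compound 1 is the only actual number in the set. Compound 3, `CC(C)C(NC(=O)n1nnc2ccccc21)C(=O)NC1CCCCC1`, is not yet measured. It differs from compound 2 in one place: cyclohexyl in place of cyclopentyl on an amide-type nitrogen. Among the compounds with values here, the cyclohexylamino group that compound 3 carries is also present in compound 1, but compound 1 and compound 3 differ elsewhere, so no measured step isolates this change on its own. A step from compound 2 to compound 3 cannot be sized against a limit; a move from the limit into the measurable range, modest at most, is what is expected, rather than a change beyond the scatter in the other direction. Compound 3 is expected at 150000 nM (range 60000 nM to 400000 nM), which would mean an expected step of an at least 1.3-fold lower number from compound 2 to compound 3 (0.12 log units; that floor lies within the scatter). The chance that this assay again reports only a limit for compound 3 is substantial.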

Compound 3, half-maximal inhibitory concentration: 112000 nM
The estimate for compound 3 lay 1.3-fold (0.13 log units) above the measured number, within the range that was stated.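

In this assay, going by these compounds alone, cyclohexyl in place of cyclopentyl on an amide-type nitrogen gives an at least 1.7-fold lower number from compound 2 to compound 3 (0.25 log units; that floor lies within the scatter), the first readout for this change at this position, and the floor of that step does not separate the two groups. The value for compound 2 is a limit and not a number, so the full size of the step stays open-ended: the limit of > 200000 nM in this assay, at which 1 of the 3 values shown sits.

With cyclohexyl held on that nitrogen, hydrogen in place of methyl on the saturated chain carbon gives a 1.0-fold higher number from compound 1 to compound 3 (0.02 log units; within the scatter), so this methyl shows no readable effect on the number in this assay.

Still open, as far as these compounds go, is whether a different group on the amide-type nitrogen, such as a phenyl ring or a longer chain, or an amine or a carboxylic acid carried on the cyclohexyl ring, would move the number beyond the scatter. Also open, from the compounds shown here alone, is whether the same methyl change would stay within the scatter with cyclopentyl on that nitrogen, and whether the change from cyclopentyl to cyclohexyl holds with other side chains.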